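This account rests on a few compounds, and the source may have more. Where it says the series, first, only, none or still open, it means among the compounds named here.

Measured in a functional assay on A20 cells (Mus musculus) for inhibition, with stated times of 1 h, 16 h and 24 h; on this read-out lower numbers stand for stronger inhibition and higher numbers for weaker inhibition:
- compound 1 `N#CC1(NC(=O)[C@@H]2C[C@@H](S(=O)(=O)c3ccccc3)C[C@H]2C(=O)N2CC3CCC(C2)O3)CC1`: 16 nM
- compound 2 `N#CC1(NC(=O)[C@@H]2C[C@@H](S(=O)(=O)c3ccccc3)C[C@H]2C(=O)Nc2ccc(F)cc2)CC1`: 391 nM

Within the data shown here, on the numbers so far, compound 2 is the weaker of the two at 391 nM. Among the measured compounds shown here, the one measured step is large: a 24-fold higher number from compound 1 to compound 2 (1.39 log units; beyond the scatter).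

The next structure is compound 3 `N#CC1(NC(=O)[C@@H]2C[C@@H](S(=O)(=O)c3ccccc3)C[C@H]2C(=O)N2CCCC2)CC1`. It keeps the shared core, with pyrrolidin-1-yl in place of (4-fluorophenyl)amino on a carbonyl carbon.

Only the measured step bears on this change, as it replaces the same (4-fluorophenyl)amino at the same place. Like compound 1 at 16 nM, compound 3 has no aromatic ring in this group, but the two groups are not the same, and a single pair cannot show how much of the step carries over. In this assay a large part of that step is expected to return, towards a lower number, though probably not all of it. The estimated change is an 8.7-fold lower number from compound 2 to compound 3 (0.94 log units; beyond the scatter). For compound 3 the expected value is 45 nM, with an estimated range of 14 nM to 150 nM.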

Compound 3, half-maximal inhibitory concentration: 29 nM
Compound 3: the middle estimate sits 1.6-fold (0.19 log units) above what was measured; low and high end bracket the measured number.
By their numbers in this assay, from the lowest: compounds 1 and 3 (each within the scatter of the next); then compound 2.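

In this assay, among these compounds, the change to pyrrolidin-1-yl on this carbonyl carbon gives a 13-fold lower number from compound 2 to compound 3 (1.13 log units; beyond the scatter) and so provides a second group, after the one in compound 1, that has neither the aromatic ring nor the amide hydrogen and stands well apart from the anilide. The other new step reads a 1.8-fold higher number from compound 1 to compound 3 (0.26 log units; within the scatter) and so the larger group of compound 1, with its additional oxygen-containing ring, cannot be told apart from the simpler pyrrolidin-1-yl on this read-out. No measurement at hand accounts for either step.

On these data alone, the aromatic ring and the amide hydrogen leave together in these compounds, so it remains open which of them goes with the weaker number: (4-fluorophenyl)(methyl)amino would keep the ring without the hydrogen, and cyclopentylamino would keep the hydrogen without the ring. Also open, as far as these compounds go, is whether a ring is needed at all on this carbonyl carbon, which an open-chain group such as dimethylamino would test against compound 3 at 29 nM in this assay on the same shared core.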